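A ring swap on compound 3

A few compounds are considered here, and "the series" means these few. Any claim that something is new, unique, unknown or untested is made for them only; others in the source may bear on it.

- Compound 1 `CN1CCN(CCCCn2c3c(c4ccccc42)C(=O)c2c[n+]([O-])c4ccccc4c2C3=O)CC1`: 30 nM
- Compound 2 `CCCN1CCN(CCCCn2c3c(c4ccccc42)C(=O)c2c[n+]([O-])c4ccccc4c2C3=O)CC1`: 870 nM
- Compound 3 `CN1CCN(CCCn2c3c(c4ccccc42)C(=O)c2c[n+]([O-])c4ccccc4c2C3=O)CC1`: 470 nM

All three numbers come from a functional assay on A-375 cells (Homo sapiens) for cytotoxicity, read by MTT assay, with a stated time of 72 h; a lower number here means a stronger inhibitor, a higher number a weaker inhibitor. The measured steps place compound 3 as follows: there is a 1.9-fold lower number from compound 2 to compound 3 (0.27 log units; within the scatter), and there is a 16-fold higher number from compound 1 to compound 3 (1.19 log units; beyond the scatter).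

Compound 4 `O=C1c2c[n+]([O-])c3ccccc3c2C(=O)c2c1c1ccccc1n2CCCN1CCC(O)CC1` keeps the shared core but differs from compound 3 in one group: 4-hydroxypiperidin-1-yl in place of 4-methylpiperazin-1-yl on a saturated chain carbon, three bonds along the chain from an aromatic nitrogen. In words, 4-hydroxypiperidin-1-yl stands in place of 4-methylpiperazin-1-yl on a saturated chain carbon, three bonds along the chain from an aromatic nitrogen.

Going by the values given here, no measured step makes this exact swap. The closest evidence is a 29-fold higher number from compound 1 to compound 2 (1.46 log units; beyond the scatter), where only the group on the piperazine ring differs. That single pair shows that a change in this ring can move the number a lot, but it gives no direction for a new ring. Only a small step is therefore expected, with a wide margin on either side. The expected change is a 1.3-fold higher number from compound 3 to compound 4 (0.11 log units; within the scatter). For compound 4 the estimated value is 600 nM, with an expected range of 150 nM to 2200 nM.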

Compound 4, half-maximal inhibitory concentration: 240 nM
Estimate against measurement, compound 4: 2.5-fold (0.40 log units) above; the measured number falls inside the stated range.
By their numbers in this assay, from the lowest: compound 1; then compounds 4, 3 and 2 (each within the scatter of the next, the first and the last beyond it).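

In this assay, the ring swap on the propyl chain gives a 2.0-fold lower number from compound 3 to compound 4 (0.29 log units; within the scatter), so this position accepts 4-hydroxypiperidin-1-yl, with one ring hetero atom and a hydrogen-bond donor, without a change beyond the scatter. Against the other two compounds, there is a 3.6-fold lower number from compound 2 to compound 4 (0.56 log units; beyond the scatter) and an 8.0-fold higher number from compound 1 to compound 4 (0.90 log units; beyond the scatter), but both steps alter the chain as well as the ring, so neither isolates the effect of the ring. Nothing available explains these differences in the numbers.

The compounds shown leave open whether the hydroxyl group or the loss of the second ring nitrogen matters more, which a plain piperidin-1-yl or a morpholin-4-yl on the same chain could help separate. They also leave open how 4-hydroxypiperidin-1-yl behaves on the longer chain of compound 1.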